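The compounds below may be only part of what the source reports. "The series", "measured", "known", "first", "only" and "open" are said of these compounds alone.

Of the compounds shown here, three have so far been tested in a functional assay on MDA-MB-436 cells (Homo sapiens) for antiproliferative activity, read by MTT assay, with a stated time of 48 h; a higher number here means a weaker inhibitor, a lower number a stronger inhibitor. In this test compound 1 `C=CS(=O)(=O)N1CCN(c2ncnc3ccc(-c4ccccc4)cc23)CC1` gives 23400 nM, compound 2 `C=CS(=O)(=O)N1CCN(c2ncnc3sc(-c4cccc5ncccc45)cc23)CC1` gives 25900 nM and compound 3 `C=CS(=O)(=O)N1CCN(c2ncnc3sc(-c4cnn(Cc5ccccc5)c4)cc23)CC1` gives 18300 nM. Repeated measurements of the same compound naturally vary, and these three numbers all lie within that scatter of one another. Compound 2 therefore stands level with the other two, and the numbers do not separate the three compounds.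

Going by the values given here, the next compound, compound 4 `C=CS(=O)(=O)N1CCN(c2ncnc3sc(C4=CCCCC4)cc23)CC1`, has no measurement yet. It has cyclohex-1-en-1-yl in place of the quinolin-5-yl of compound 2, on an aromatic carbon of a five-membered aromatic ring with 1 sulfur, next to the ring sulfur (cyclohex-1-en-1-yl in place of quinolin-5-yl on an aromatic carbon). Among the compounds with values here, no two measured compounds differ in one place only, so no measured step shows directly what such a swap does. The closest guide is compound 3, which has a different group on that carbon and gives 18300 nM, within the scatter of compound 2. No change beyond the scatter is therefore expected in this assay, and no clear direction can be expected either. The estimated step of a 1.2-fold lower number from compound 2 to compound 4 (0.07 log units; within the scatter) is expected to stay within the scatter. Compound 4 is estimated at 22000 nM, with an expected range from 11000 nM to 44000 nM.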

Compound 4, half-maximal inhibitory concentration: > 50000 nM
Compound 4: a limit, no number (the forecaster's own chance of this, stated with the estimate: 10%); at least 2.2-fold (0.35 log units) between middle value and limit.
By their numbers in this assay, from the lowest: compounds 3, 1 and 2 (each within the scatter of the next). At a limit, above all of these: compound 4.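

Replacing quinolin-5-yl with cyclohex-1-en-1-yl on the aromatic carbon next to the ring sulfur gives the only step among these compounds that changes one place alone, an at least 1.9-fold higher number from compound 2 to compound 4 (0.28 log units; that floor lies within the scatter). Compound 4 gives a limit of the test and not a number, and it is the only compound shown to do so: the limit of > 50000 nM in this assay, at which 1 of the 4 values shown sits. The earlier compounds shown here gave numbers that could not be told apart, whereas this swap shows that a change on this carbon can take a compound to the limit, although the floor of the step alone does not clear the scatter.

The compounds shown cannot separate the parts of this swap: the aromatic rings that leave, the ring nitrogen that leaves, the smaller count of heavy atoms and the double bond that enters all change together. A fully saturated cyclohexyl group or a pyridine ring on the same carbon would pull these parts apart, and a number in place of the limit would be needed to give the step a true size.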